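Amide replacement of the carboxylic acid on the triazole chain

This account rests on a few compounds, and the source may have more. Where it says the series, first, only, none or still open, it means among the compounds named here.

Compounds measured so far:
- compound 1 `CN(CCNCc1cn(-c2ccccc2Cl)nn1)CCNc1ccnc2cc(Cl)ccc12`: 12000 nM
- compound 2 `CN(CCNCc1cn(CC(=O)O)nn1)CCNc1ccnc2cc(Cl)ccc12`: > 200000 nM
- compound 3 `CN(CCNCc1cn(Cc2nc3cc(Cl)ccc3[nH]2)nn1)CCNc1ccnc2cc(Cl)ccc12`: 65000 nM

In a functional assay on HCC827 cells (Homo sapiens) for antiproliferative activity, read by sulforhodamine B assay, with a stated time of 72 h (on this read-out lower numbers stand for stronger inhibition and higher numbers for weaker inhibition), compound 1 gives 12000 nM. Compound 3 gives 65000 nM in this assay. For compound 2 the value > 200000 nM is a limit of this assay, not a number, as the limit of > 200000 nM in this assay, at which 1 of the 3 values shown sits, records; compound 2 therefore stands at the weak end of the series. The step of an at least 16-fold higher number from compound 1 to compound 2 (1.22 log units; beyond the scatter) and the step of an at least 3.0-fold lower number from compound 2 to compound 3 (0.48 log units; beyond the scatter) both show that an aryl or heteroaryl group on the triazole nitrogen side gives a lower number than the carboxymethyl group, while a 5.4-fold higher number from compound 1 to compound 3 (0.73 log units; beyond the scatter) separates the two aryl variants.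

Compound 4 `CN(CCNCc1cn(CC(=O)Nc2cccc3ccc(O)cc23)nn1)CCNc1ccnc2cc(Cl)ccc12` differs from compound 2 by (7-hydroxynaphthalen-1-yl)amino in place of hydroxy on a carbonyl carbon. This change removes the carboxylic acid and introduces an aromatic group, the direction that both relevant steps favour. Because the steps to compound 1 and compound 3 were an at least 16-fold higher number from compound 1 to compound 2 (1.22 log units; beyond the scatter) and an at least 3.0-fold lower number from compound 2 to compound 3 (0.48 log units; beyond the scatter), a lower number than the limit of compound 2 is expected for compound 4 in this assay, with the step of an at least 10-fold lower number from compound 2 to compound 4 (1.00 log units; beyond the scatter). Compound 4 is therefore estimated at 20000 nM, in the range 4000 nM to 100000 nM.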

Compound 4, half-maximal inhibitory concentration: 86000 nM
For compound 4 the middle estimate is 4.3-fold (0.63 log units) below the measured one, within the range that was stated.
By their numbers in this assay, from the lowest: compound 1; then compounds 3 and 4 (each within the scatter of the next). At a limit, above all of these: compound 2.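

In this assay, replacing hydroxy on the carbonyl carbon with (7-hydroxynaphthalen-1-yl)amino gives an at least 2.3-fold lower number from compound 2 to compound 4 (0.36 log units; beyond the scatter), so this position accepts a much larger group, with two aromatic rings, and still gives a measurable value. Only a lower bound on the size of this step can be read, since the value for compound 2 is a limit: the limit of > 200000 nM in this assay, at which 1 of the 4 values shown sits. Compound 3 gives 65000 nM and compound 4 gives 86000 nM, within the scatter of each other, so the new group on this chain gives a number on a par with the (5-chloro-1H-benzimidazol-2-yl)methyl group.

The compounds shown do not separate the contribution of the amide link from that of the naphthalene rings, which a plain amino group on the same carbonyl carbon would address. Going by these compounds, the role of the ring hydroxy also stays open, and naphthalen-1-ylamino without it would test that.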